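The compounds below may be only part of what the source reports. "The series", "measured", "known", "first", "only" and "open" are said of these compounds alone.

Working notes on the series in a physicochemical assay for lipophilicity; on this read-out higher numbers stand for higher lipophilicity and lower numbers for lower lipophilicity. Compound 1 `Cc1nc(C)c(COC(=O)NCC(=O)Oc2ccc(-c3cc(=O)c4c(O)c(O)c(O)cc4o3)cc2)nc1C` gives 2.1, compound 2 `Cc1nc(C)c(COC(=O)N[C@H](C)C(=O)Oc2ccc(-c3cc(=O)c4c(O)c(O)c(O)cc4o3)cc2)nc1C` gives 1.53 and compound 3 `Cc1nc(C)c(COC(=O)N[C@H](CC(C)C)C(=O)Oc2ccc(-c3cc(=O)c4c(O)c(O)c(O)cc4o3)cc2)nc1C` gives 1.69. Compound 1 is the highest of the three, with two steps beyond the scatter: a number 0.57 log units lower from compound 1 to compound 2 (beyond the scatter) and a number 0.41 log units lower from compound 1 to compound 3 (beyond the scatter). Compound 3 stands with compound 2 in the lower pair, whose gap lies within the scatter: a number 0.16 log units higher from compound 2 to compound 3 (within the scatter).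

Compound 4 `CC[C@H](C)[C@@H](NC(=O)OCc1nc(C)c(C)nc1C)C(=O)Oc1ccc(-c2cc(=O)c3c(O)c(O)c(O)cc3o2)cc1` has the same atoms as compound 3, joined differently: sec-butyl in place of isobutyl on a saturated chain carbon bound to an amide-type nitrogen and a carbonyl carbon. In words, this is sec-butyl in place of isobutyl on a saturated chain carbon bound to an amide-type nitrogen and a carbonyl carbon.

For the measured compounds named here, no measured step covers this exchange. The two steps from compound 1 replace hydrogen on that carbon, which does not happen here, so their size does not carry over. The closer guide is a number 0.16 log units higher from compound 2 to compound 3 (within the scatter), an added isopropyl on the chain that stayed within the scatter. No step beyond the scatter is therefore expected in this assay. The estimated step is a number 0.01 log units higher from compound 3 to compound 4 (within the scatter). Compound 4 is expected at 1.7, with an estimated range from 1.35 to 2.05.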

Compound 4, partition coefficient: 2.83
The estimate for compound 4 lay 1.13 log units below the measured number; measured number above the stated range.
By their numbers in this assay, from the lowest: compounds 2 and 3 (each within the scatter of the next); then compound 1; then compound 4.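

In this assay, this position responds to how the same atoms are joined, not only to which atoms are present: sec-butyl in place of isobutyl gives a number 1.14 log units higher from compound 3 to compound 4 (beyond the scatter) and brings a defined stereocentre to the group. The earlier compounds shown here showed only replacements of hydrogen on this carbon that lowered the number, whereas sec-butyl gives a number 0.73 log units higher from compound 1 to compound 4 (beyond the scatter) and so reverses that direction, with compound 2 and compound 3 as the cases that go against any general rise. Set against methyl, the same group gives a number 1.30 log units higher from compound 2 to compound 4 (beyond the scatter) and no evidence at hand accounts for the size of these steps.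

Still open, as far as these compounds go, is whether the high number belongs to sec-butyl alone or also appears with isopropyl, tert-butyl or a straight butyl chain at this place, and whether the other stereoisomer of sec-butyl behaves in the same way. Also open, from the compounds shown here alone, is how a group carrying an amine or a carboxylic acid would stand on this carbon in the same series.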